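The source may hold more compounds than are shown below. What is called first, only, known or untested is meant among the compounds shown, and "the series" means these compounds.

The series shares one core, differing only in the chain carried on the sulfur. Compound 1 `CCCCC(Sc1nc(Cl)cc(Nc2nc(-c3ccc(Cl)cc3)cs2)n1)C(=O)O` gives 3800 nM in an assay for inhibition of Polyunsaturated fatty acid 5-lipoxygenase (Homo sapiens), read by HPLC, with a stated time of 10 min; a lower number here means a stronger inhibitor, a higher number a weaker inhibitor. Compound 2 `CCC(Sc1nc(Cl)cc(Nc2nc(-c3ccc(Cl)cc3)cs2)n1)C(=O)O` gives 6600 nM in this assay. Within the data shown here, of the two numbers measured so far compound 2 holds the higher one, yet the step of a 1.7-fold higher number from compound 1 to compound 2 (0.24 log units; within the scatter) lies within the scatter, so no order between compound 1 and compound 2 can be read from it. Compound 3 `O=C(O)CSc1nc(Cl)cc(Nc2nc(-c3ccc(Cl)cc3)cs2)n1` is not yet measured. It differs from compound 2 by hydrogen in place of ethyl on a saturated chain carbon bound to a carbonyl carbon and a sulfur. Among the measured compounds shown here, the only measured step that bears on this change is the one from compound 1 to compound 2, which removed the same group from a chain carbon three bonds along the chain from the carbonyl carbon and the sulfur, and that step stayed within the scatter. A comparable outcome is therefore expected in this assay: a step of modest size, if anything toward a higher number, but nothing the scatter would not cover. The expected step is a 1.4-fold higher number from compound 2 to compound 3 (0.13 log units; within the scatter). Compound 3 is estimated at 9000 nM, with a range from 4000 nM to 20000 nM.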

Compound 3, half-maximal inhibitory concentration: > 10000 nM
Compound 3: only a limit was reported; the forecaster's own chance of this, stated with the estimate: 10%; at least 1.1-fold (0.04 log units) between middle value and limit.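

Compound 3 gives only a limit of the assay in this assay, not a number: the limit of > 10000 nM in this assay, at which 1 of the 3 values shown sits.

Among these compounds, the step of an at least 2.6-fold higher number from compound 1 to compound 3 (0.42 log units; beyond the scatter) is the first to lie beyond the scatter, and it shows that the saturated chain carbon bound to a carbonyl carbon and a sulfur is not indifferent to substitution: the full change, hydrogen in place of butyl, can be read as a loss of inhibition, which the shortening from butyl to ethyl did not show. The change from ethyl to hydrogen alone stays unresolved, since the step of an at least 1.5-fold higher number from compound 2 to compound 3 (0.18 log units; that floor lies within the scatter) gives only a floor that lies within the scatter, so it cannot yet be said whether ethyl already gives compound 2 an advantage over hydrogen.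

On these data alone, how far the true value of compound 3 lies beyond its limit stays unknown, and with it the real size of both steps. The compounds shown also leave open whether a longer chain than butyl or a phenyl ring at this carbon would give a lower number, and whether a methyl ester or an amide could stand in place of the carboxylic acid.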